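Nitro in place of methoxy, compound 2 to compound 3

This account rests on a few compounds, and the source may have more. Where it says the series, first, only, none or still open, it means among the compounds named here.

Measured so far:
- compound 1, `O=C(CN1CCN(c2ccccc2)CC1)N1CCN(c2nnc(-c3ccccc3)c(-c3ccccc3)n2)CC1`: in a functional assay on MCF7 cells (Homo sapiens) for cytotoxicity, read by MTT assay, with a stated time of 24 h (on this read-out lower numbers stand for stronger inhibition and higher numbers for weaker inhibition), compound 1 gives only a limit, > 963000 nM.
- compound 2, `COc1ccc(N2CCN(CC(=O)N3CCN(c4nnc(-c5ccccc5)c(-c5ccccc5)n4)CC3)CC2)cc1`: in this assay compound 2 gives only a limit, > 910000 nM.

Compound 2 thus stands at a limit of this assay and nowhere on a numbered scale. Compound 2 sits at the limit (the limit of > 910000 nM in this assay, at which 1 of the 2 values shown sits). Compound 1 sits at the limit (the limit of > 963000 nM in this assay, at which 1 of the 2 values shown sits). Among the compounds with values here, the one measured step, a step that the two limits leave unreadable from compound 1 to compound 2, is unreadable between the two limits.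

Compound 3, `O=C(CN1CCN(c2ccc([N+](=O)[O-])cc2)CC1)N1CCN(c2nnc(-c3ccccc3)c(-c3ccccc3)n2)CC1`, differs from compound 2 by nitro in place of methoxy on an aromatic carbon. Within the data shown here, no readable measured step bears on this change; the only step is the unreadable one, so neither direction nor size can be drawn from the measured pair. The expectation for compound 3 in this assay therefore rests solely on the two limits: compound 3 is expected at 1000000 nM, with a range of 300000 nM to 3000000 nM, most likely again reported as a limit. The step implied by this estimate, a step that the limit leaves unreadable from compound 2 to compound 3, is expected to be none beyond the scatter.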

Compound 3, half-maximal inhibitory concentration: > 886000 nM
Compound 3 ended at the assay's limit (the forecaster's own chance of this, stated with the estimate: 90%); the middle value is on the limit's open side.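

In this assay compound 3 gives > 886000 nM as a limit of the assay, not a number. Within the data shown here, compound 1, compound 2 and compound 3 all stand at limits, so no step among them can be read. Going by these compounds, whether hydrogen, methoxy or nitro on the aromatic carbon makes any difference in this assay remains open.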